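Working notes: from trifluoromethoxy to carboxy

The source may hold more compounds than are shown below. What is called first, only, known or untested is meant among the compounds shown, and "the series" means these compounds.

Values so far in an ADME assay on HEK293 cells (Homo sapiens) for cytotoxicity, with a stated time of 72 h; on this read-out higher numbers stand for an effect only at larger amounts of compound and lower numbers for an effect already at smaller amounts
compound 1 (`Cc1cc(NC(=O)Nc2ccc(C(F)(F)F)cc2)c2ccccc2n1`) gives 25000 nM
compound 2 (`Cc1cc(NC(=O)Nc2ccc(OC(F)(F)F)cc2)c2ccccc2n1`) gives 14000 nM

Compound 2 sits level with compound 1 on these numbers. Going by the values given here, the single measured step (a 1.8-fold lower number from compound 1 to compound 2 (0.25 log units; within the scatter)) puts trifluoromethoxy in place of trifluoromethyl on an aromatic carbon. Compound 3 (`Cc1cc(NC(=O)Nc2ccc(C(=O)O)cc2)c2ccccc2n1`) is not yet measured in this assay and has carboxy in place of trifluoromethoxy on an aromatic carbon, para to a large group (carboxy in place of trifluoromethoxy on an aromatic carbon). Among the compounds with values here, that measured step stays within the scatter, but no measured compound carries carboxy, so it offers only a weak guide here. A moderate move toward a higher number is expected, with wide uncertainty. The expected size is a 2.5-fold higher number from compound 2 to compound 3 (0.40 log units; beyond the scatter) as a rough estimate. For compound 3 the expected value is 35000 nM (estimated range 12000 nM to 100000 nM).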

Compound 3, half-maximal effective concentration: > 25000 nM
Compound 3 gave a limit, no number; the forecaster's own chance of this, stated with the estimate: 35%; the middle value lies beyond the limit too.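

Compound 3 gives a limit, not a number: the limit of > 25000 nM in this assay, at which 1 of the 3 values shown sits. Going by these compounds alone, the earlier compounds covered only two fluorinated groups at this position, para to a large group, whereas carboxy gives an at least 1.7-fold higher number from compound 2 to compound 3 (0.25 log units; that floor lies within the scatter). That floor means the change cannot yet be called a real shift from compound 2. Carboxy in place of trifluoromethyl gives a number no lower from compound 1 to compound 3 (the limit leaves the size open), so this step cannot be read.

The compounds shown leave open how far the true value of compound 3 lies past its limit, and so whether carboxy changes the read-out at all. From the compounds shown here alone, whether the result is specific to carboxy also stays open, and a methyl ester or an amine at the same aromatic carbon would bear on that question.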